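Anilinoquinazoline thioacetamides: aryl amide variation

This account rests on a few compounds, and the source may have more. Where it says the series, first, only, none or still open, it means among the compounds named here.

Measured so far in a functional assay on NCI-H1975 cells (Homo sapiens) for inhibition, read by MTT assay, with a stated time of 72 h; on this read-out higher numbers stand for weaker inhibition and lower numbers for stronger inhibition:
compound 1, `O=C(CSc1nc(Nc2ccccc2)c2ccccc2n1)Nc1ccccc1F`, 9350 nM
compound 2, `O=C(CSc1nc(Nc2ccccc2)c2ccccc2n1)Nc1ccccc1Cl`, 9610 nM
compound 3, `O=C(CSc1nc(Nc2ccccc2)c2ccccc2n1)Nc1cccc(Cl)c1`, 8460 nM

All three share one core and differ only in the aryl group on the amide nitrogen. Compound 3 stands together with the other two: the steps of a 1.1-fold lower number from compound 1 to compound 3 (0.04 log units; within the scatter) and a 1.1-fold lower number from compound 2 to compound 3 (0.06 log units; within the scatter) are both within the scatter, as is a 1.0-fold higher number from compound 1 to compound 2 (0.01 log units; within the scatter). Nothing among these three separates one amide aryl group from another.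

Compound 4, `O=C(CSc1nc(Nc2ccccc2)c2ccccc2n1)Nc1cccc([N+](=O)[O-])c1`, is not yet measured. It differs from compound 3 by nitro in place of chloro on an aromatic carbon. For the measured compounds named here, none of the measured steps exchanges a halogen for a nitro group; the closest are the swap of chloro for fluoro, a 1.0-fold higher number from compound 1 to compound 2 (0.01 log units; within the scatter), and the moves of the halogen around the ring, a 1.1-fold lower number from compound 1 to compound 3 (0.04 log units; within the scatter) and a 1.1-fold lower number from compound 2 to compound 3 (0.06 log units; within the scatter), every one of them within the scatter. Going by the values given here, with no measured step bearing directly on a nitro group, the expected step of a 1.0-fold higher number from compound 3 to compound 4 (0.00 log units; within the scatter) is taken as none beyond the scatter, with the range widened to allow for the untested group. Compound 4 is therefore estimated at 8500 nM in this assay, within 3000 nM to 25000 nM.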

Compound 4, half-maximal inhibitory concentration: 17900 nM
The estimate for compound 4 lay 2.1-fold (0.32 log units) below the measured number; measured number inside the range.
By their numbers in this assay, from the lowest: compounds 3, 1, 2 and 4 (each within the scatter of the next, the first and the last beyond it).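

In this assay, the exchange at this aromatic carbon gives the only step among these compounds that lies beyond the scatter, a 2.1-fold higher number from compound 3 to compound 4 (0.33 log units; beyond the scatter), so the substituent on the amide aryl group can affect the read-out, though only modestly here. The separation is narrow and does not set compound 4 apart from the whole set: a 1.9-fold higher number from compound 2 to compound 4 (0.27 log units; within the scatter) and a 1.9-fold higher number from compound 1 to compound 4 (0.28 log units; within the scatter) both remain within the scatter, and each of these steps also changes the aryl group more broadly than a simple exchange of chloro for nitro. No measurement of any property of these compounds is available to explain the step from chloro to nitro.

Still open, going by these compounds, is whether nitro elsewhere on the ring would give a similar step, and whether an amine, a methoxy group or a carboxylic acid on the same aromatic carbon would leave the number with the halogen compounds or move it in either direction. Also open is whether a longer chain between the sulfur and the carbonyl, or substitution on the shared core, would have a larger effect than any change to the amide aryl group shown here.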